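Benzyl in place of bromo: from compound 3 to compound 4

A few compounds are considered here, and "the series" means these few. Any claim that something is new, unique, unknown or untested is made for them only; others in the source may bear on it.

Of the compounds shown here, three on a shared core have been measured in an assay on HeLa cells for displacement of a labelled ligand from 5-hydroxytryptamine receptor 6 (Homo sapiens); a higher number here means a weaker inhibitor, a lower number a stronger inhibitor. Compound 1 `CSc1nc2ccc(Br)cn2c(=N)c1S(=O)(=O)c1ccccc1` gives 56 nM. Compound 2 `CSc1nc2c(C)cccn2c(=N)c1S(=O)(=O)c1ccccc1` gives 3.4 nM. Compound 3 `CSc1nc2c(C)cc(Br)cn2c(=N)c1S(=O)(=O)c1ccccc1` gives 12 nM, the second highest of the three numbers; its nearest neighbour is compound 2 and its furthest is compound 1. The two single-point steps that lead to compound 3 run in opposite directions: a 4.7-fold lower number from compound 1 to compound 3 (0.67 log units; beyond the scatter), whereas a 3.5-fold higher number from compound 2 to compound 3 (0.55 log units; beyond the scatter).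

Compound 4 `CSc1nc2c(C)cc(Cc3ccccc3)cn2c(=N)c1S(=O)(=O)c1ccccc1` has not yet been measured. It differs from compound 3 in one place: benzyl in place of bromo on an aromatic carbon. Going by the values given here, only one measured step touches this carbon, the entry of bromo from compound 2 to compound 3, which raised the number by a modest amount. Among the compounds with values here, no measured pair shows a benzyl entering anywhere, so the data give no direct guide to the new group. The expectation is therefore built from compound 3 as the anchor, with a wide range on both sides: a step of a 1.3-fold higher number from compound 3 to compound 4 (0.10 log units; within the scatter) is expected, essentially none beyond the scatter. Compound 4 is thus estimated at 15 nM, with a range from 3 nM to 75 nM.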

Compound 4, half-maximal inhibitory concentration: 60 nM
Compound 4: middle estimate off by 4.0-fold (0.60 log units), on the low side, within the range that was stated.
By their numbers in this assay, from the lowest: compound 2; then compound 3; then compounds 1 and 4 (each within the scatter of the next).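

At this carbon, two atoms from the ring nitrogen and meta to the methyl group, exchanging bromo for benzyl in this assay gives a 5.0-fold higher number from compound 3 to compound 4 (0.70 log units; beyond the scatter), so the position does not accept every group equally. Measured against hydrogen, benzyl gives an 18-fold higher number from compound 2 to compound 4 (1.25 log units; beyond the scatter), a larger step than bromo's a 3.5-fold higher number from compound 2 to compound 3 (0.55 log units; beyond the scatter), and both groups tried here on the methyl-bearing core raise the number, although two groups are too few to establish a trend with size. Nothing at hand explains these rises.

Going by these compounds, whether the loss follows from the added carbon count or from the aromatic ring remains open, and a phenyl group, an ethyl chain or a methoxy group at this carbon would help separate those readings, while an amine would test a different kind of substituent. Going by these compounds alone, it is also unknown whether benzyl would produce a similar step on a core lacking the methyl group, since the only comparison without that methyl is the bromo compound 1, and hydrogen at this carbon has no counterpart there.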